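Methyl removal on the pyridine amide of compound 2

This account rests on a few compounds, and the source may have more. Where it says the series, first, only, none or still open, it means among the compounds named here.

Compound 2 `Cc1cccc(NC(=O)COc2ccc3cc(/C=C4/SC(=O)NC4=O)ccc3c2)n1` holds the lowest number of the three compounds measured in an assay on isolated protein for inhibition of histone deacetylase 4 (Homo sapiens), with a stated time of 1 h; on this read-out lower numbers stand for stronger inhibition and higher numbers for weaker inhibition: it gives 1100 nM. Compound 3 `CCOc1ccc2nc(NC(=O)COc3ccc4cc(/C=C5/SC(=O)NC5=O)ccc4c3)sc2c1` is nearest to it, giving 3600 nM, a gap beyond the scatter. Compound 1 `O=C(CN1C(=O)S/C(=C/c2ccccn2)C1=O)Nc1nc2ccccc2s1` is furthest, giving 9300 nM, also beyond the scatter. Within the data shown here, no step between two measured compounds differing in a single place is available, so the effect of the change considered here has to be taken from the parent alone.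

Compound 4 `O=C(COc1ccc2cc(/C=C3/SC(=O)NC3=O)ccc2c1)Nc1ccccn1` differs from compound 2 only in this : hydrogen in place of methyl on an aromatic carbon. The shared core, the linker and the amide are untouched. A change this small, a methyl leaving and a hydrogen entering on the aromatic ring, is expected to move the number little, most likely within the scatter, with a slight lean towards a higher number. The expected step from compound 2 to compound 4 is a 1.4-fold higher number from compound 2 to compound 4 (0.13 log units; within the scatter). Compound 4 is thus estimated at 1500 nM in this assay, with a range of 600 nM to 4000 nM.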

Compound 4, half-maximal inhibitory concentration: 17000 nM
Beside the measured number, compound 4's estimate is 11-fold (1.05 log units) below it, and the stated range ends below it.
By their numbers in this assay, from the lowest: compound 2; then compound 3; then compounds 1 and 4 (each within the scatter of the next).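

In this assay the swap of 6-methylpyridin-2-yl to pyridin-2-yl gives a 15-fold higher number from compound 2 to compound 4 (1.19 log units; beyond the scatter), so the methyl on this aromatic carbon, next to the ring nitrogen, matters far more than its single heavy atom might suggest. Among these compounds, this is the first comparison that isolates one place, as the earlier compounds differ from one another in several places and could not assign any part of their spread to a single group. No measurement at hand accounts for the size of this step.

On these data alone, whether the effect is particular to methyl remains open: an ethyl, a methoxy, a chlorine or an amine on the same carbon would test that. Also open, as far as these compounds go, is whether a methyl on any other carbon of the pyridine ring gives a step of similar size.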